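The source may report more compounds than this note shows. Statements on the series, on what has been measured and on what is new or still open speak of the compounds shown alone.

Compound 3 `C[C@@H]1CCCN1c1c(C#N)c2c(N)nc(N)nc2n1C` gives the highest of the three numbers in an assay on isolated protein for inhibition of Leucine-rich repeat serine/threonine-protein kinase 2 variant G2019S (Homo sapiens), read by TR-FRET and LanthaScreen, with stated times of 50 min and 30 min, in the presence of a further agent that is not named here (on this read-out lower numbers stand for stronger inhibition and higher numbers for weaker inhibition), at 217 nM. Compound 1 `Cc1nn(C2COC2)cc1Nc1nc(N)c2c(C#N)c(N3CCC[C@H]3C)n(C)c2n1` gives 25 nM, and compound 2 `C[C@@H]1CCCN1c1c(C#N)c2c(N)ncnc2n1C` gives 11 nM; the steps read an 8.7-fold higher number from compound 1 to compound 3 (0.94 log units; beyond the scatter) and a 20-fold higher number from compound 2 to compound 3 (1.30 log units; beyond the scatter). Compound 4 `Cc1nn(C)cc1Nc1nc(N)c2c(C#N)c(N3CCC[C@H]3C)n(C)c2n1` carries 1,3-dimethyl-1H-pyrazol-4-yl in place of hydrogen on a nitrogen on an aromatic ring. Going by the values given here, only the step between compound 1 and compound 3 bears directly on this change: there too a closely related pyrazolyl group stands on that nitrogen, and removing it raised the number modestly. The step from compound 2 concerns an amino group on an aromatic carbon and offers no guide here. A lowering of similar size is therefore expected, a 7.2-fold lower number from compound 3 to compound 4 (0.86 log units; beyond the scatter). For compound 4 the estimate in this assay is 30 nM, within 12 nM to 80 nM.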

Compound 4, half-maximal inhibitory concentration: 30 nM
Estimate against measurement, compound 4: no gap at the digits printed, within the range that was stated.
By their numbers in this assay, from the lowest: compound 2; then compounds 1 and 4 (each within the scatter of the next); then compound 3.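

In this assay, a second pyrazolyl group on this nitrogen also lowers the number, a 7.2-fold lower number from compound 3 to compound 4 (0.86 log units; beyond the scatter), so the effect does not depend on the oxetan-3-yl group. With methyl in place of oxetan-3-yl on the aromatic nitrogen, the result is a 1.2-fold higher number from compound 1 to compound 4 (0.08 log units; within the scatter), which shows that this exchange makes no readable difference. The (1,3-dimethyl-1H-pyrazol-4-yl)amino group still does not surpass hydrogen on the aromatic carbon, with a 2.7-fold higher number from compound 2 to compound 4 (0.44 log units; beyond the scatter). Going by these compounds, it remains open whether a piperidine or a carboxylic acid on that aromatic nitrogen would leave the number unchanged. No evidence given here accounts for these steps.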